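The source may report more compounds than this note shows. Statements on the series, on what has been measured and on what is new or still open speak of the compounds shown alone.

Working notes on the series.

Three compounds have numbers in an assay for inhibition of Alpha amylase (Homo sapiens), read by spectrophotometry, with stated times of 10 min and 20 min; on this read-out lower numbers stand for stronger inhibition and higher numbers for weaker inhibition. Compound 1 `CCn1nc(Cn2nnc(-c3ccccn3)n2)cc1C` gives 540 ug/mL in this assay. Compound 2 `Cc1cc(Cn2nnnc2Cc2ccccc2)n[nH]1` gives 1970 ug/mL. Compound 3 `CCn1nc(Cn2nnc(Cc3ccccc3)n2)cc1C` gives 2360 ug/mL. On these numbers compound 2 stands second highest of the three: its nearest neighbour is compound 3, whose value lies within the scatter of it, and the furthest is compound 1, whose value lies lower by more than the scatter. For the measured compounds named here, the one single-point step measured so far is a 4.4-fold higher number from compound 1 to compound 3 (0.64 log units; beyond the scatter), a change on an aromatic carbon that does not involve the ring nitrogen at issue here.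

Compound 4 `CCn1nc(Cn2nnnc2Cc2ccccc2)cc1C` is not yet measured. It differs from compound 2 by ethyl in place of hydrogen on an aromatic nitrogen. Going by the values given here, no measured step changes a substituent on that aromatic nitrogen, so nothing in hand speaks directly to this change. Compounds 2 and 3, which differ in two places including that same nitrogen, give values within the scatter of each other, which gives no sign of a large effect from this position. The expectation for this assay is therefore a step of no more than the scatter, in no particular direction, a 1.0-fold higher number from compound 2 to compound 4 (0.01 log units; within the scatter). Compound 4 is estimated at 2000 ug/mL, with a range of 900 ug/mL to 4500 ug/mL.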

Compound 4, half-maximal inhibitory concentration in the Alpha amylase assay: 23 ug/mL
For compound 4 the middle estimate is 87-fold (1.94 log units) above the measured one, and the stated range ends above it.
By their numbers in the Alpha amylase assay, from the lowest: compound 4; then compound 1; then compounds 2 and 3 (each within the scatter of the next).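

For the compounds shown here, the substituent on this aromatic nitrogen proves to be a strong determinant of the read-out in the Alpha amylase assay: ethyl in place of hydrogen gives an 86-fold lower number from compound 2 to compound 4 (1.93 log units; beyond the scatter), a larger step than any other so far. The earlier compounds shown here offered no single-place comparison at this nitrogen, and this pair now shows that the position is far from silent, with a small alkyl group enough to produce a large change in inhibition. In a physicochemical assay for lipophilicity (on this read-out higher numbers stand for higher lipophilicity and lower numbers for lower lipophilicity), compound 2 gives 1.62 and compound 4 gives 2.1, so the same change also raises lipophilicity, and the two read-outs move together in this one pair, though a single pair cannot show that the rise in lipophilicity accounts for the stronger inhibition: the measured partition coefficient of compound 2, 1.62, and of compound 4, 2.1, a number 0.48 log units higher (beyond the scatter)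

Only hydrogen and ethyl stand on this nitrogen in the compounds shown, so it remains open whether the trend continues with a longer chain such as propyl, or survives with a chain ending in a carboxylic acid or an amine, which would help separate the size of the group from its lipophilicity. Going by these compounds, it also remains open whether a step of this size carries over to the pyridin-2-yl series of compound 1.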